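Chloro to cyclopentenyl on the quinolone core of the series

This account rests on a few compounds, and the source may have more. Where it says the series, first, only, none or still open, it means among the compounds named here.

Two compounds of the series have numbers in an assay on isolated protein for inhibition of tyrosine-protein kinase receptor UFO (Homo sapiens), read by FRET and Z'-LYTE, with a stated time of 1.5 h; a higher number here means a weaker inhibitor, a lower number a stronger inhibitor. Compound 1 `Cc1c(C(=O)Nc2ccc(Oc3ncnc4[nH]cc(-c5ccccc5)c34)c(F)c2)c(=O)c2cc(Cl)ccc2n1C` gives 1890 nM and stands highest of the two. Compound 2 `Cc1ccc2c(c1)c(=O)c(C(=O)Nc1ccc(Oc3ncnc4[nH]cc(-c5ccccc5)c34)c(F)c1)cn2C` differs from compound 1 in several places. In this assay, for the measured compounds named here, compound 2 gives 150 nM, a lower number that lies beyond the scatter; no single-point step connects these two, so only their two values are read side by side.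

Compound 3 `Cc1c(C(=O)Nc2ccc(Oc3ncnc4[nH]cc(-c5ccccc5)c34)c(F)c2)c(=O)c2cc(C3=CCCC3)ccc2n1C` is not yet measured. It differs from compound 1 as follows: cyclopent-1-en-1-yl in place of chloro on an aromatic carbon. Going by the values given here, no measured pair in this set shows what such an exchange does in this assay, so the expectation rests on the value of compound 1 alone. A modest step is expected from compound 1 to compound 3 in this assay, a 1.6-fold lower number from compound 1 to compound 3 (0.20 log units; within the scatter), toward a lower number but with wide uncertainty. Compound 3 is therefore estimated at 1200 nM, within a range from 400 nM to 4000 nM.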

Compound 3, half-maximal inhibitory concentration: 3320 nM
Estimate against measurement, compound 3: 2.8-fold (0.44 log units) below; the range from low to high includes it.
By their numbers in this assay, from the lowest: compound 2; then compounds 1 and 3 (each within the scatter of the next).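

In this assay, the exchange of chloro for cyclopent-1-en-1-yl gives a 1.8-fold higher number from compound 1 to compound 3 (0.24 log units; within the scatter). For the compounds shown here, this is the first single-place step, and it shows that on this aromatic carbon, para to a fused ring, one chlorine can give way to five carbons, a five-membered non-aromatic ring and a double bond without a change that can be read in this measurement. Nothing on hand explains why the two values stay this close.

This single pair gives no trend for the position, and the reading holds only for the exchange on the core of compound 1. Open, as far as these compounds go, is how a saturated cyclopentyl ring, a phenyl ring, an amine or a carboxylic acid on the same carbon would read in this assay.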